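Butyl Chain to Amino Ester: Cytotoxicity Outlook

The source may hold more compounds than are shown below. What is called first, only, known or untested is meant among the compounds shown, and "the series" means these compounds.

Compound 1 `CCCCc1c(F)c(N)c2c(=O)cc(-c3ccc(N)c(F)c3)oc2c1F` gives in a functional assay on HeLa cells (Homo sapiens) for cytotoxicity, read by neutral red uptake, with a stated time of 3 days (on this read-out lower numbers stand for stronger inhibition and higher numbers for weaker inhibition), only the assay limit > 100000 nM. Compound 2 `CCOC(=O)c1c(F)c(N)c2c(=O)cc(-c3ccc(N)c(F)c3)oc2c1F` likewise gives only the limit > 100000 nM. Compound 3 `CCC(=O)OCc1c(F)c(N)c2c(=O)cc(-c3ccc(N)c(F)c3)oc2c1F` gives a number, 69000 nM.

Compound 1 thus stands at the limit rather than at a number, and the same holds for one other value here: the limit of > 100000 nM in this assay, at which 2 of the 3 values shown sit. For the measured compounds named here, the one readable step toward a number is that to compound 3, which carries propanoyloxy in place of propyl on a saturated chain carbon bound to an aromatic carbon: an at least 1.4-fold lower number from compound 1 to compound 3 (0.16 log units; that floor lies within the scatter). The step from the ester-bearing compound 2 reads the same way, an at least 1.4-fold lower number from compound 2 to compound 3 (0.16 log units; that floor lies within the scatter), while a step that the two limits leave unreadable from compound 1 to compound 2.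

Compound 4 `CN(C)CCCC(=O)OCc1c(F)c(N)c2c(=O)cc(-c3ccc(N)c(F)c3)oc2c1F` differs from compound 1 as follows: ((3-(dimethylamino)propyl)carbonyl)oxy in place of propyl on a saturated chain carbon bound to an aromatic carbon. Going by the values given here, the change resembles the one leading to compound 3, and for compound 4 the expected step is estimated as an at least 1.6-fold lower number from compound 1 to compound 4 (0.22 log units; that floor lies within the scatter). Compound 4 is therefore estimated at 60000 nM, with a range from 20000 nM to 200000 nM.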

Compound 4, half-maximal inhibitory concentration: 4500 nM
Beside the measured number, compound 4's estimate is 13-fold (1.12 log units) above it, outside the stated range (below it).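

For the compounds shown here, on the saturated chain carbon bound to an aromatic carbon, the propanoyloxy ester of compound 3 had given only a floor within the scatter, whereas adding (dimethylamino)methyl to that ester gives a 15-fold lower number from compound 3 to compound 4 (1.19 log units; beyond the scatter), the one step here between two actual numbers. The steps from the other two compounds are also large, an at least 22-fold lower number from compound 1 to compound 4 (1.34 log units; beyond the scatter) and an at least 22-fold lower number from compound 2 to compound 4 (1.34 log units; beyond the scatter), and both are floors rather than exact sizes. Compound 1 and compound 2 stand at a limit and not at a number: the limit of > 100000 nM in this assay, at which 2 of the 4 values shown sit.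

The compounds shown leave open whether the lower number depends on the dimethylamino nitrogen itself or on the longer chain carrying it. A plain butanoyloxy chain, a primary amine or a carboxylic acid at the same chain end would help separate these two readings.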